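Isopropyl in place of isopropoxy on the benzyl ring

The source may hold more compounds than are shown below. What is called first, only, known or untested is meant among the compounds shown, and "the series" means these compounds.

Compound 2 `CC(C)Oc1ccc(CN2CCC(CCCC(=O)c3ncco3)CC2)cc1` gives the lowest of the two numbers measured in an assay on isolated protein for inhibition of Fatty-acid amide hydrolase 1 (Homo sapiens) (a lower number here means a stronger inhibitor, a higher number a weaker inhibitor), namely 14 nM, while compound 1 `Cc1ccc(CN2CCC(CCCC(=O)c3ncco3)CC2)cc1` gives 400 nM. Among the measured compounds shown here, the single measured step, a 29-fold lower number from compound 1 to compound 2 (1.46 log units; beyond the scatter), exchanged methyl for isopropoxy. Compound 3 `CC(C)c1ccc(CN2CCC(CCCC(=O)c3ncco3)CC2)cc1` differs from compound 2 by isopropyl in place of isopropoxy on an aromatic carbon. For the measured compounds named here, no measured step isolates the removal of the oxygen while the three-carbon branch stays, so the direction rests on analogy alone and a moderate loss is taken as the likelier outcome. Compound 3 is therefore expected at 40 nM, in the range 12 nM to 130 nM. The expected step is a 2.9-fold higher number from compound 2 to compound 3 (0.46 log units; beyond the scatter).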

Compound 3, half-maximal inhibitory concentration: 3.6 nM
Beside the measured number, compound 3's estimate is 11-fold (1.05 log units) above it, outside the stated range (below it).
By their numbers in this assay, from the lowest: compound 3; then compound 2; then compound 1.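

In this assay the oxygen of isopropoxy proves dispensable on this aromatic carbon: taking it out gives a 3.9-fold lower number from compound 2 to compound 3 (0.59 log units; beyond the scatter) and no loss. The gain over methyl therefore needs no oxygen, with isopropyl alone giving a 110-fold lower number from compound 1 to compound 3 (2.05 log units; beyond the scatter) on the shared core. No evidence on the reason for this is available here. The compounds shown leave open whether tert-butyl or cyclohexyl on this carbon would lower the number further. They also leave open whether an amine or a carboxylic acid would be tolerated there.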